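The compounds below may be only part of what the source reports. "The series", "measured", "known", "first", "only" and "open" are said of these compounds alone.

Measured so far:

Compound 1, `O=C1C(Nc2ccc(I)cc2)=CC(=O)c2c1nc1n2[C@H]2OC[C@@H](O)[C@H]2OC1` — in a functional assay on MGC-803 cells (Homo sapiens) for inhibition, read by sulforhodamine B assay (a higher number here means a weaker inhibitor, a lower number a stronger inhibitor), compound 1 gives 2150 nM.
Compound 2, `CCc1ccc(NC2=CC(=O)c3nc4n(c3C2=O)[C@H]2OC[C@@H](O)[C@H]2OC4)cc1` — in this assay compound 2 gives 1290 nM.

Of the compounds shown here, two sharing one core have been measured, and compound 2 holds the smaller of the two numbers. Within the data shown here, the gap to compound 1, however, lies within the usual scatter of this kind of measurement, so the two cannot be separated on the values shown, and no single-place step between them is given here.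

The next compound, compound 3, `Cc1ccc(NC2=CC(=O)c3nc4n(c3C2=O)[C@H]2OC[C@@H](O)[C@H]2OC4)cc1C`, differs from compound 2 in one place: 3,4-dimethylphenyl in place of 4-ethylphenyl on an amine nitrogen. The group that leaves and the group that enters carry the same atoms, joined differently, and neither brings a donor or an acceptor.

Among the measured compounds shown here, no measured step of comparable kind is available to anchor the expectation, so it rests on the values of compound 2 and compound 1 alone. With both anchors within scatter of each other and a change that keeps the atom count, the step in this assay from compound 2 to compound 3 is expected to be small, with no direction beyond the scatter, a 1.1-fold higher number from compound 2 to compound 3 (0.04 log units; within the scatter). Compound 3 is estimated at 1400 nM, with a range from 500 nM to 4000 nM.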

Compound 3, half-maximal inhibitory concentration: 860 nM
The estimate for compound 3 lay 1.6-fold (0.21 log units) above the measured number; low and high end bracket the measured number.
By their numbers in this assay, from the lowest: compounds 3, 2 and 1 (each within the scatter of the next, the first and the last beyond it).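

Exchanging 4-ethylphenyl for 3,4-dimethylphenyl on the amine nitrogen gives a 1.5-fold lower number from compound 2 to compound 3 (0.18 log units; within the scatter) in this assay, so the two compounds cannot be told apart in this assay. This is the only single-place step shown, and it gives the first direct reading at this position: with the atoms of the group unchanged and only their joining altered, the number does not leave the scatter. The result therefore offers no sign that this particular rearrangement of the group matters in this assay, although a single step cannot show that the position is insensitive more generally, and no measurement is available that bears on the step.

On these data alone, it remains open whether a group of a different kind in place of the 3,4-dimethylphenyl on the amine nitrogen, such as a pyridyl, or a phenyl carrying a carboxylic acid or an amine, would move the number beyond the scatter. As far as these compounds go, it is equally open whether a longer chain, such as 4-butylphenyl, would do so, or whether the number would stay where compound 2 and compound 3 lie.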